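The compounds below may be only part of what the source reports. "The series", "measured", "known", "first", "only" and "open" are said of these compounds alone.

Compound 1 `O[C@H]1Cc2ccccc2C1NC1CCN(CCCc2c[nH]c3ccc(-n4cnnc4)cc23)CC1` gives 37 nM in an assay on CHO cells for displacement of a labelled ligand from 5-hydroxytryptamine receptor 1D (Homo sapiens); a lower number here means a stronger inhibitor, a higher number a weaker inhibitor.
Compound 2 `c1ccc(CNC2CCN(CCCc3c[nH]c4ccc(-n5cnnc5)cc34)CC2)cc1` gives 4.6 nM in this assay.

Compound 2 has the lowest number of the two measured compounds, and its nearest neighbour is compound 1, separated by a step of an 8.0-fold lower number from compound 1 to compound 2 (0.91 log units; beyond the scatter). Compound 3 `CN(Cc1ccsc1)C1CCN(CCCc2c[nH]c3ccc(-n4cnnc4)cc23)CC1` carries methyl((thiophen-3-yl)methyl)amino in place of benzylamino on a saturated ring carbon. Among the measured compounds shown here, the single measured step concerns a different replacement on the same amine nitrogen and therefore bears on this change only loosely; it shows that the group on that nitrogen can move the number by an 8.0-fold lower number from compound 1 to compound 2 (0.91 log units; beyond the scatter). For the measured compounds named here, with no measured example of an added methyl on this nitrogen, or of a thiophene ring in place of the benzene ring, the expected step in this assay is small and its direction uncertain. Compound 3 is therefore estimated at 8 nM, within a range of 2 nM to 30 nM, which amounts to an expected step of a 1.7-fold higher number from compound 2 to compound 3 (0.24 log units; within the scatter).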

Compound 3, half-maximal inhibitory concentration: 1.5 nM
Compound 3: middle estimate off by 5.3-fold (0.73 log units), on the high side; the measured number lies below the stated range.
By their numbers in this assay, from the lowest: compound 3; then compound 2; then compound 1.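

In this assay, the step to methyl((thiophen-3-yl)methyl)amino on the saturated ring carbon is a 3.1-fold lower number from compound 2 to compound 3 (0.49 log units; beyond the scatter). This shows that the number at this position can still fall when the entering group has no hydrogen-bond donor and a five-membered aromatic ring replaces the six-membered one. Measured against the hydroxyindanyl amine, the same group gives a 25-fold lower number from compound 1 to compound 3 (1.39 log units; beyond the scatter), so the span across this position is wider than the earlier pair showed, and nothing available explains the gain.

The step combines two changes, so the share of the added methyl and that of the thiophene ring remain unseparated. N-methylbenzylamino, (thiophen-3-yl)methylamino and the isomeric (thiophen-2-yl)methyl group would each bear on that question, and how a furan ring would behave at this position also remains open.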